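From 2-fluoro-5-iodophenyl to 6-methoxypyridin-3-yl on the carbonyl carbon

The compounds below may be only part of what the source reports. "The series", "measured", "known", "first", "only" and "open" are said of these compounds alone.

The compounds share one core and differ in the group on a carbonyl carbon. In a functional assay on MCF7 cells (Homo sapiens) for antiproliferative activity, read by MTT assay, with a stated time of 24 h (on this read-out higher numbers stand for weaker inhibition and lower numbers for stronger inhibition), compound 1 `COC(=O)c1scc(-c2ccc(NC(=O)c3ccc4ccccc4c3)cc2)c1OC`, with naphthalen-2-yl, gives 90 nM. Compound 2 `COC(=O)c1scc(-c2ccc(NC(=O)c3cccc(C(F)(F)F)c3)cc2)c1OC`, with 3-(trifluoromethyl)phenyl, gives 26200 nM. Compound 3 `COC(=O)c1scc(-c2ccc(NC(=O)c3cc(I)ccc3F)cc2)c1OC`, with 2-fluoro-5-iodophenyl, gives 22500 nM, which places compound 3 together with compound 2 at the high end of the numbers. Two large steps leave naphthalen-2-yl: a 290-fold higher number from compound 1 to compound 2 (2.46 log units; beyond the scatter) and a 250-fold higher number from compound 1 to compound 3 (2.40 log units; beyond the scatter). The exchange of one single-ring group for another is much smaller: a 1.2-fold lower number from compound 2 to compound 3 (0.07 log units; within the scatter).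

Compound 4 `COC(=O)c1scc(-c2ccc(NC(=O)c3ccc(OC)nc3)cc2)c1OC` carries 6-methoxypyridin-3-yl in place of 2-fluoro-5-iodophenyl on a carbonyl carbon. This is again an exchange of one single-ring group for another, so the closest guide is a 1.2-fold lower number from compound 2 to compound 3 (0.07 log units; within the scatter). The two large steps involve the loss of naphthalen-2-yl and do not apply directly. For the measured compounds named here, no measured compound has a hetero atom in this ring, so that part of the change is untested, and the range is kept wide. No step beyond the scatter is therefore expected in this assay. The expected step is a 1.1-fold lower number from compound 3 to compound 4 (0.05 log units; within the scatter). Compound 4 is estimated at 20000 nM, with an expected range of 4000 nM to 60000 nM.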

Compound 4, half-maximal inhibitory concentration: 5250 nM
Estimate against measurement, compound 4: 3.8-fold (0.58 log units) above, within the range that was stated.
By their numbers in this assay, from the lowest: compound 1; then compound 4; then compounds 3 and 2 (each within the scatter of the next).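

In this assay the single-ring groups on the carbonyl carbon are no longer interchangeable: compound 2 and compound 3 stay within the scatter of each other (a 1.2-fold lower number from compound 2 to compound 3 (0.07 log units; within the scatter)), while 6-methoxypyridin-3-yl gives a modest step beyond the scatter from each of them (a 4.3-fold lower number from compound 3 to compound 4 (0.63 log units; beyond the scatter) and a 5.0-fold lower number from compound 2 to compound 4 (0.70 log units; beyond the scatter)). This step is still only a small part of the distance to naphthalen-2-yl, which remains large (a 58-fold higher number from compound 1 to compound 4 (1.77 log units; beyond the scatter)), so within the compounds shown, a single-ring group can change the read-out at this position without coming close to compound 1. Nothing available explains why the step from compound 3 to compound 4 goes in this direction.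

Compound 4 differs from compound 3 in several features at once, with the ring hetero atom and the methoxy group entering together as the fluoro and iodo groups leave, so the share of each stays unresolved. The compounds shown leave open how a methoxyphenyl group or an unsubstituted pyridinyl group would read at this position, and either would help separate the methoxy group from the ring nitrogen.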